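The source may report more compounds than this note shows. Statements on the series, on what has been measured and on what is new or still open speak of the compounds shown alone.

Compounds 1, 2 and 3 share one core. Compound 1 `N[C@H]1CC[C@H](Nc2c(C(=O)NCc3ccco3)nc(Br)c3cccnc23)CC1`, compound 2 `N[C@H]1CC[C@H](Nc2c(C(=O)NCc3cccc(C(F)(F)F)c3)nc(Br)c3cccnc23)CC1` and compound 3 `N[C@H]1CC[C@H](NC(=O)c2nc(Br)c3cccnc3c2NCc2ccc(F)cc2)CC1` have all been run in a functional assay on HEY cells (Homo sapiens) for cytotoxicity, read by MTT assay, with a stated time of 72 h; on this read-out lower numbers stand for stronger inhibition and higher numbers for weaker inhibition. In this assay compound 1 gives only a limit, > 10000 nM. In this assay compound 2 gives 12000 nM, while compound 3 gives 7100 nM; compound 2 thus holds the higher of the two readable numbers, and compound 3 sits within the scatter of it, so no order between them is claimed. The step that the limit leaves unreadable from compound 1 to compound 2 cannot be sized, since the limit of > 10000 nM in this assay, at which 1 of the 3 values shown sits, leaves its starting point unknown.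

Compound 4 `N[C@H]1CC[C@H](Nc2c(C(=O)Nc3ccccc3)nc(Br)c3cccnc23)CC1` has not yet been measured. It differs from compound 2 by phenyl in place of 3-(trifluoromethyl)benzyl on an amide-type nitrogen. Going by the values given here, no measured step bears on this change: the only step in the set, a step that the limit leaves unreadable from compound 1 to compound 2, is unreadable and concerns a different exchange on the same chain. Among the compounds with values here, with both readable values close together and no step of readable size anywhere in the set, the working assumption is that compound 4 is expected to stay near compound 2, the expected step of a 1.2-fold lower number from compound 2 to compound 4 (0.08 log units; within the scatter) being of no size beyond the scatter. The estimate for compound 4 in this assay is 10000 nM, between 3500 nM and 30000 nM, with a real chance that only a limit is returned.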

Compound 4, half-maximal inhibitory concentration: 1000 nM
Beside the measured number, compound 4's estimate is 10-fold (1.00 log units) above it, outside the stated range (below it).
By their numbers in this assay, from the lowest: compound 4; then compounds 3 and 2 (each within the scatter of the next).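

In this assay, going by these compounds alone, phenyl in place of 3-(trifluoromethyl)benzyl on an amide-type nitrogen gives a 12-fold lower number from compound 2 to compound 4 (1.08 log units; beyond the scatter), the first step of readable size and the first sign that this position can move the number beyond the scatter. Phenyl in place of (furan-2-yl)methyl on the same nitrogen points the same way, with an at least 10-fold lower number from compound 1 to compound 4 (1.00 log units; beyond the scatter), so among these three compounds the group bound directly through its aromatic ring, in compound 4, holds the lower number, and neither group attached through a saturated chain carbon matches it. The value of compound 1 is a limit: the limit of > 10000 nM in this assay, at which 1 of the 4 values shown sits.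

The change from compound 2 to compound 4 removes both the chain carbon and the trifluoromethyl, and a plain benzyl on the amide-type nitrogen would be needed to part these two contributions. Also open, from the compounds shown here alone, is whether the lower number holds for a phenyl carrying a methoxy group or for a cyclohexyl on the same nitrogen.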